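Halogen swap on the benzylidene arm of the shared core

The source may report more compounds than this note shows. Statements on the series, on what has been measured and on what is new or still open speak of the compounds shown alone.

Measured so far:
compound 1, `Cc1ccc2c(c1)/C(=c1/sc(=Cc3ccc(C=O)c(C=O)c3)c(=O)n1CCN(C)C)C(=O)N2` — 1030 nM
compound 2, `CN(C)CCn1c(=O)c(=Cc2ccc(O)cc2)s/c1=C1\C(=O)Nc2ccc(Cl)cc21` — 2460 nM
compound 3, `CN(C)CCn1c(=O)c(=Cc2ccc(O)cc2)s/c1=C1\C(=O)Nc2ccc(F)cc21` — 1480 nM

In a functional assay on HT-29 cells (Homo sapiens) for inhibition, read by MTT assay, with a stated time of 72 h (a lower number here means a stronger inhibitor, a higher number a weaker inhibitor), compound 1 gives the lowest of the three numbers. Compound 3 sits nearest, within the scatter, while compound 2 lies beyond it. Going by the values given here, the one measured step, a 1.7-fold lower number from compound 2 to compound 3 (0.22 log units; within the scatter), changes only a fluoro for a chloro on the core and stays within the scatter.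

Compound 4, `Cc1ccc2c(c1)/C(=c1/sc(=Cc3ccc(F)c(F)c3)c(=O)n1CCN(C)C)C(=O)N2`, differs from compound 1 by 3,4-difluorophenyl in place of 3,4-diformylphenyl on a double-bonded chain carbon bound to an aromatic carbon. Among the compounds with values here, no measured pair exchanges the diformylphenyl for a fluorinated ring, so the only step at hand is the halogen exchange between compound 2 and compound 3, which was small. Nothing here points to a move beyond the scatter in either direction for this assay.

Compound 4 is therefore expected to stay close to compound 1, at an estimated 1200 nM (range 400 nM to 3600 nM). The expected step of a 1.2-fold higher number from compound 1 to compound 4 (0.07 log units; within the scatter) is within the scatter.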

Compound 4, half-maximal inhibitory concentration: 7430 nM
Compound 4: the middle estimate sits 6.2-fold (0.79 log units) below what was measured; measured number above the stated range.
By their numbers in this assay, from the lowest: compounds 1, 3 and 2 (each within the scatter of the next, the first and the last beyond it); then compound 4.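

At the double-bonded chain carbon bound to an aromatic carbon, 3,4-difluorophenyl in place of 3,4-diformylphenyl gives a 7.2-fold higher number from compound 1 to compound 4 (0.86 log units; beyond the scatter) in this assay, so the groups carried on this ring can move the number well past the usual scatter. Going by these compounds alone, the halogen exchange a 1.7-fold lower number from compound 2 to compound 3 (0.22 log units; within the scatter) gave no sign of a step of this size, and the two halogen steps therefore do not describe this position. No measurement at hand accounts for the step from the diformylphenyl to the difluorophenyl.

Going by these compounds, it remains open whether both formyl groups are needed for the lower number of compound 1, or whether a single formyl, a nitrile or a carboxylic acid on the ring would serve as well. On these data alone, the dimethylaminoethyl chain is common to all four compounds, so the effect of a longer chain or a different amine there also stays unknown.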